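Adding a Methyl to the Acetyl Arm of Compound 1

The compounds below may be only part of what the source reports. "The series", "measured", "known", "first", "only" and "open" are said of these compounds alone.

Going by the values given here, compound 1 `CC(=O)N1CCN(c2nc(=O)c3cc(C(F)(F)F)cc([N+](=O)[O-])c3s2)CC1` gives 83.9 ug/mL in a physicochemical assay for solubility, read by HPLC (a lower number here means a less soluble compound, a higher number a more soluble compound), the higher of the two numbers measured so far. Compound 2 `O=C(c1cccc(F)c1)N1CCN(c2nc(=O)c3cc(C(F)(F)F)cc([N+](=O)[O-])c3s2)CC1` gives 0.2 ug/mL in this assay; the step of a 420-fold lower number from compound 1 to compound 2 (2.62 log units; beyond the scatter) is the only measured one. Compound 3 `CCC(=O)N1CCN(c2nc(=O)c3cc(C(F)(F)F)cc([N+](=O)[O-])c3s2)CC1` differs from compound 1 by methyl in place of hydrogen on a saturated chain carbon bound to a carbonyl carbon. The measured step swaps methyl for 3-fluorophenyl, a far larger change than one added methyl, so it offers little guidance here. A small decrease, close to the scatter, is expected for compound 3: a 2.1-fold lower number from compound 1 to compound 3 (0.32 log units; beyond the scatter). Compound 3 is therefore estimated at 40 ug/mL, between 15 ug/mL and 90 ug/mL.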

Compound 3, solubility: 3.29 ug/mL
Estimate against measurement, compound 3: 12-fold (1.08 log units) above, outside the stated range (below it).
By their numbers in this assay, from the lowest: compound 2; then compound 3; then compound 1.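

Adding a single methyl on a saturated chain carbon bound to a carbonyl carbon gives a large step in this assay (a 26-fold lower number from compound 1 to compound 3 (1.41 log units; beyond the scatter)), so even the smallest change here can move the number far. Ethyl in place of 3-fluorophenyl on a carbonyl carbon is also a large step (a 16-fold higher number from compound 2 to compound 3 (1.22 log units; beyond the scatter)), which leaves compound 3 well apart from both neighbours. Nothing measured here explains the size of either step. Going by these compounds, how a longer chain or an amine on this carbon would read remains open, and so does whether the number would keep falling as the chain grows.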